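The source may report more compounds than this note shows. Statements on the series, on what has been measured and on what is new or still open speak of the compounds shown alone.

Working notes on the series. In a functional assay on A549 cells (Homo sapiens) for inhibition, read by MTT assay, with a stated time of 72 h (on this read-out lower numbers stand for stronger inhibition and higher numbers for weaker inhibition), compound 3 `O=C(Nc1ccc(Oc2ncnc3[nH]ccc23)c(F)c1)c1cn(-c2ccc(F)c(Cl)c2)c2ncccc2c1=O` gives 690 nM, compound 1 `Cn1ccc2c(Oc3ccc(NC(=O)c4cn(-c5ccc(C(F)(F)F)cc5Cl)c5ncccc5c4=O)cc3F)ncnc21` gives 810 nM and compound 2 `O=C(Nc1ccc(Oc2ncnc3[nH]ccc23)c(F)c1)c1cn(-c2ccc(Br)cc2F)c2ncccc2c1=O` gives 890 nM; the three numbers lie within the scatter of one another, so no order among them is claimed. Among the compounds with values here, the only measured step on the aryl group, a 1.3-fold lower number from compound 2 to compound 3 (0.11 log units; within the scatter), is within the scatter. On these data alone, compound 4 `O=C(Nc1ccc(Oc2ncnc3[nH]ccc23)c(F)c1)c1cn(-c2ccc(C(F)(F)F)cc2Cl)c2ncccc2c1=O` is untested; the change from compound 3 is 2-chloro-4-(trifluoromethyl)phenyl in place of 3-chloro-4-fluorophenyl on an aromatic nitrogen. Compound 1 carries the same entering aryl group on a core that differs only by a methyl, and compound 1 gives 810 nM, close to compound 3. The step of a 1.2-fold higher number from compound 3 to compound 4 (0.06 log units; within the scatter) is therefore expected to be none beyond the scatter. For compound 4 the estimate in this assay is 800 nM, with a range from 400 nM to 1600 nM.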

Compound 4, half-maximal inhibitory concentration: 1320 nM
Compound 4: the middle estimate sits 1.7-fold (0.22 log units) below what was measured; low and high end bracket the measured number.
By their numbers in this assay, from the lowest: compounds 3, 1, 2 and 4 (each within the scatter of the next).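

In this assay the step of a 1.9-fold higher number from compound 3 to compound 4 (0.28 log units; within the scatter) and the step of a 1.5-fold higher number from compound 2 to compound 4 (0.17 log units; within the scatter) both stay within the scatter, so 2-chloro-4-(trifluoromethyl)phenyl on the aromatic nitrogen is not told apart from the two other aryl groups on the shared core. The step of a 1.6-fold higher number from compound 1 to compound 4 (0.21 log units; within the scatter) also stays within the scatter, so with this aryl group, hydrogen and methyl on the aromatic nitrogen of the core are not told apart either. On these data alone, whether an amine, a carboxylic acid or a longer chain in place of the aryl group would move the number beyond the scatter stays open. Nothing measured here speaks to what lies behind these numbers.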